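This account rests on a few compounds, and the source may have more. Where it says the series, first, only, none or still open, it means among the compounds named here.

Working notes on the series.

Three compounds have numbers in a functional assay on NCI-H460 cells (Homo sapiens) for antiproliferative activity, read by CCK-8 assay, with a stated time of 72 h, tested at 8 uM; a higher number here means a stronger effect of the compound at the concentration tested, a lower number a weaker effect. Compound 1 `CCCCn1cnc2c(Nc3cccc(Cl)c3)nc(NCOCc3ccc(/C=C/C(=O)Nc4ccccc4N)cc3)nc21` gives 51.1%. Compound 3 `CC(C)n1cnc2c(Nc3cccc(Cl)c3)nc(NCOCc3ccc(/C=C/C(=O)Nc4ccccc4N)cc3)nc21`, which carries the change (isopropyl in place of butyl on an aromatic nitrogen), gives 61.1%. The step this change made, a number 10 percentage points higher from compound 1 to compound 3 (within the scatter), is a small one and does not rise out of the noise of repeated runs. Compound 2 `CCCCn1cnc2c(NCc3ccc(C(=O)Nc4ccccc4N)cc3)nc(Cl)nc21` gives 23.7%, the lowest of the three; its gap to compound 1 and to compound 3 lies beyond the usual scatter, so compound 2 is read as the weaker member of the set.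

Compound 4 `CC(C)n1cnc2c(NCc3ccc(C(=O)Nc4ccccc4N)cc3)nc(Cl)nc21` has not been measured in this assay. It stands to compound 2 as compound 3 stands to compound 1: the change is isopropyl in place of butyl on an aromatic nitrogen, the same change that was made from compound 1 to compound 3. The difference between the core of compound 2 and the core of compound 1 is not broken down here.

The expectation for compound 4 rests on a single earlier instance of the same change, the step of a number 10 percentage points higher from compound 1 to compound 3 (within the scatter), which stayed within the scatter; the step from compound 2 to compound 4 is therefore expected to be about as small, a number 6.3 percentage points higher from compound 2 to compound 4 (within the scatter), with the starting point set by compound 2 at 23.7%. Among the compounds with values here, on that basis compound 4 is estimated at 30% in this assay, most likely between 15% and 45%, the width reflecting that only one example of the change is available and that the two cores are not the same.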

Compound 4, a percentage reported as inhibition, at one concentration (the size of the read-out at that concentration, not a potency): 80.5%
For compound 4 the middle estimate is 50.5 percentage points below the measured one; measured number outside the range, above it.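

Carried onto the core of compound 2, isopropyl in place of butyl on an aromatic nitrogen gives in this assay a large step, a number 56.8 percentage points higher from compound 2 to compound 4 (beyond the scatter), so the small step seen on the core of compound 1 is no guide to its size here. The two steps do not match, and the size of this change differs from one core to the other in this series: the same change on two cores in this assay, a number 10 percentage points higher (within the scatter) from compound 1 to compound 3 and a number 56.8 percentage points higher (beyond the scatter) from compound 2 to compound 4, 46.8 percentage points apart, beyond the scatter of two such steps. This shows only that, for these two matched pairs, the effect of the change cannot be transferred from one core to the other at face value; it does not show which of the structural differences between the two cores goes with the difference in step, why the steps differ, or how the change would behave on any third core.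

Open, from the compounds shown here alone, is whether the large step on the core of compound 2 is particular to isopropyl or is shared by other groups on the same aromatic nitrogen, such as ethyl, cyclopentyl or a longer chain such as hexyl. Also open, going by these compounds, is how the step behaves on a core that carries only part of the difference between the two cores, for instance an amine in place of the chlorine of compound 2.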